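The source may report more compounds than this note shows. Statements on the series, on what has been measured and on what is new or still open speak of the compounds shown alone.

Series notes. Compound 1 `Cc1nn2c(-c3nc4cc(Cl)c(F)cc4[nH]3)c(-c3ccc(F)cc3)nc2s1`, compound 2 `Cc1nn2c(-c3nc4cc(Cl)c(F)cc4[nH]3)c(-c3ccccc3)nc2s1` and compound 3 `Cc1nn2c(-c3nc4ccccc4[nH]3)c(-c3ccccc3)nc2s1` share a core and have each been run in a functional assay on A-375 cells (Homo sapiens) for antiproliferative activity, read by MTT assay; a lower number here means a stronger inhibitor, a higher number a weaker inhibitor. In this assay compound 1 gives 17700 nM, compound 2 gives 20800 nM and compound 3 gives 19900 nM. Compound 2 and compound 1 differ by fluoro in place of hydrogen on an aromatic carbon; the step of a 1.2-fold lower number from compound 2 to compound 1 (0.07 log units; within the scatter) keeps the two within the scatter. How the core of compound 2 differs from the core of compound 3 is not broken down here; the two values lie within the scatter of each other. Compound 4 `Cc1nn2c(-c3nc4cc(F)ccc4[nH]3)c(-c3ccccc3)nc2s1` is not yet measured. It differs from compound 3 by fluoro in place of hydrogen on an aromatic carbon. This is the same kind of change as from compound 2 to compound 1, but not the same one: in compound 1 the fluoro is para to a large group, whereas in compound 4 it sits on a ring that is part of a fused or bridged system of two rings, meta to a fused ring and para to a fused ring. For compound 4 the step from compound 3 is estimated as a 1.1-fold lower number from compound 3 to compound 4 (0.04 log units; within the scatter), resting on the earlier step of a 1.2-fold lower number from compound 2 to compound 1 (0.07 log units; within the scatter) for the same kind of change. In this assay compound 4 is expected near 18000 nM, likely between 9000 nM and 40000 nM.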

Compound 4, half-maximal inhibitory concentration: 18100 nM
Compound 4: middle estimate off by 1.0-fold (0.00 log units), on the low side; the range from low to high includes it.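

In this assay, fluoro in place of hydrogen on an aromatic carbon gives a 1.1-fold lower number from compound 3 to compound 4 (0.04 log units; within the scatter). Set beside the earlier step for the same kind of change, this one shows no difference between the two cores: the same change on two cores in this assay, a 1.2-fold lower number (0.07 log units; within the scatter) from compound 2 to compound 1 and a 1.1-fold lower number (0.04 log units; within the scatter) from compound 3 to compound 4, 1.1-fold (0.03 log units) apart, within the scatter of two such steps The agreement is between two steps that both stay within the scatter, at different places on the molecule, so it shows only that this small change left the number within the scatter on both cores; it does not show that a step of real size would carry from one core to another, nor does it give a reliable size or direction for the change.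

The compounds shown carry only hydrogen, fluoro or chloro on their aromatic rings and keep the methyl on the shared core. Left open is whether an amine, a carboxylic acid or a methoxy group on either aromatic ring, or a longer chain in place of the methyl, would move the number beyond the scatter.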